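Amine swap on the shared core of compound 2

The source may hold more compounds than are shown below. What is called first, only, known or untested is meant among the compounds shown, and "the series" means these compounds.

Measured so far:
compound 2 `COc1cc(/C=C/c2nc(N3CCCC3)c3sccc3n2)cc(OC)c1OC`: 681000 nM
compound 1 `COc1cc(/C=C/c2nc(Cl)cc(NC(C)C)n2)cc(OC)c1OC`: < 40000 nM

Within the data shown here, in a functional assay on L02 cells (Homo sapiens) for inhibition, read by Griess assay, with stated times of 1 h and 24 h (on this read-out higher numbers stand for weaker inhibition and lower numbers for stronger inhibition), compound 2 gives 681000 nM, the only number in the set. Compound 1 gives < 40000 nM, a limit of the assay rather than a number, (the limit of < 40000 nM in this assay, at which 1 of the 2 values shown sits). Compound 3 `COc1cc(/C=C/c2nc(NCc3ccc(C)cc3)c3sccc3n2)cc(OC)c1OC` differs from compound 2 by (4-methylbenzyl)amino in place of pyrrolidin-1-yl on an aromatic carbon. Among the measured compounds shown here, no measured pair differs in one place, so the size of this step has no precedent here; a moderate gain beyond the scatter is expected, the step from compound 2 to compound 3 being estimated at a 2.7-fold lower number from compound 2 to compound 3 (0.44 log units; beyond the scatter). Compound 3 is estimated at 250000 nM, expected between 60000 nM and 900000 nM.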

Compound 3, half-maximal inhibitory concentration: > 1000000 nM
Compound 3: no number, only a limit (the forecaster's own chance of this, stated with the estimate: 20%); middle value at least 4.0-fold (0.60 log units) away from the limit.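

In this assay compound 3 gives a limit and not a number: the limit of > 1000000 nM in this assay, at which 1 of the 3 values shown sits.

On this aromatic carbon, next to the ring nitrogen, (4-methylbenzyl)amino in place of pyrrolidin-1-yl gives an at least 1.4-fold higher number from compound 2 to compound 3 (0.16 log units; that floor lies within the scatter). The change therefore shows no gain in inhibition, although the floor of the step does not by itself establish a loss.

The compounds shown leave open whether morpholin-4-yl or an unsubstituted benzylamino on this carbon would give a lower number than compound 2.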